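A few compounds are considered here, and "the series" means these few. Any claim that something is new, unique, unknown or untested is made for them only; others in the source may bear on it.

Compound 1 `CC1(c2ccc(-c3cccc(/C(N)=N\O)c3)cc2)CC(S(=O)(=O)c2ccc(F)cc2)=C(c2ccc(/C(N)=N\O)cc2)O1` was tested in an ADME assay on HepG2 cells (Homo sapiens) for cytotoxicity, read by MTT assay, with a stated time of 72 h (on this read-out lower numbers stand for higher toxicity in this test and higher numbers for lower toxicity in this test), where compound 1 gives 19000 nM. For the measured compounds named here, that is the lowest number among the three compounds measured so far. Compound 2 `CC1(Cc2ccccc2)CC(S(=O)(=O)c2c(F)cccc2F)=C(c2ccc(/C(N)=N\O)cc2)O1` gives 91400 nM in this assay, and compound 3 `CC1(Cc2ccccc2)CC(S(=O)(=O)c2ccc(F)cc2F)=C(c2ccc(/C(N)=N\O)cc2)O1` gives 90600 nM. Compound 2 and compound 3 differ only in the fluorinated ring on the sulfonyl sulfur, and that exchange gave a 1.0-fold lower number from compound 2 to compound 3 (0.00 log units; within the scatter). Compound 1 differs from both of them in more than one place, so its value can only be set beside theirs: compound 1 sits clearly below both, meaning it is the more toxic of the three in this test.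

Compound 4 `COc1cc(-c2ccc(C3(C)CC(S(=O)(=O)c4ccc(F)cc4)=C(c4ccc(/C(N)=N\O)cc4)O3)cc2)cc(OC)c1OC` has not yet been measured. It is built from compound 1 by a group of 12 heavy atoms (9 carbon, 3 oxygen; one six-membered aromatic ring of carbon only) in place of a group of 10 heavy atoms (7 carbon, 2 nitrogen, 1 oxygen; one six-membered aromatic ring of carbon only), on an aromatic carbon. Going by the values given here, no measured step touches this part of the molecule; the single step available, between compound 2 and compound 3, concerns the ring on the sulfonyl sulfur and stayed within the scatter. There is thus no direct guide, and compound 1 is the only close anchor. For compound 4 the expected outcome is a step of a 1.6-fold lower number from compound 1 to compound 4 (0.20 log units; within the scatter), small and toward a somewhat lower number, with a flat result well within reach. The estimated value for compound 4 in this assay is 12000 nM, with a range from 4000 nM to 40000 nM.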

Compound 4, half-maximal cytotoxic concentration: > 50000 nM
Compound 4: only a limit was reported; the forecaster's own chance of this, stated with the estimate: 5%; middle value at least 4.1-fold (0.61 log units) away from the limit.
By their numbers in this assay, from the lowest: compound 1; then compounds 3 and 2 (each within the scatter of the next).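

For the compounds shown here, at this aromatic carbon, para to a large group, the earlier compounds offered no step, and the new result shows that the group placed here can change the read-out: 3,4,5-trimethoxyphenyl in place of the group of 10 heavy atoms gave an at least 2.6-fold higher number from compound 1 to compound 4 (0.42 log units; beyond the scatter) in this assay. The toxicity of compound 1 in this test therefore does not come from the shared core alone, and this exchange moved the number beyond the scatter, whereas the fluorine change on the sulfonyl ring gave a 1.0-fold lower number from compound 2 to compound 3 (0.00 log units; within the scatter). The result for compound 4 is a limit and not a number, so the step gives only a smallest size: the limit of > 50000 nM in this assay, at which 1 of the 4 values shown sits.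

Going by these compounds, the two exchanged groups differ in several features at once, including their counts of hydrogen-bond donors and acceptors, so it remains open which feature goes with the change. A plain phenyl, a phenyl with a single methoxy, or a ring carrying an amine or a carboxylic acid at this place could begin to separate these features.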